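Bromo in Place of Ethyl on a Thiophene Thiosemicarbazone

The compounds below may be only part of what the source reports. "The series", "measured", "known", "first", "only" and "open" are said of these compounds alone.

Compound 1, `S=C(N/N=C/c1cccs1)Nc1cccc2ccccc12`: > 100000 nM
Compound 2, `CCc1ccc(NC(=S)N/N=C/c2cccs2)cc1`: > 100000 nM
Compound 3, `C=CCNC(=S)N/N=C/c1cccs1`: > 100000 nM

Of the compounds shown here, three have been measured in a functional assay on NCI-H460 cells (Homo sapiens) for inhibition, read by sulforhodamine B assay, with a stated time of 48 h; a higher number here means a weaker inhibitor of growth, a lower number a stronger inhibitor of growth. In it compound 1 gives > 100000 nM, which is a limit of the assay and not a number. Compound 2 gives > 100000 nM, also a limit. Compound 3 gives > 100000 nM, again a limit. All three values sit at the limit of > 100000 nM in this assay, at which 3 of the 3 values shown sit. Compound 2 therefore stands at the limit together with the other two, and no order among the three can be drawn from these values.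

Compound 4, `S=C(N/N=C/c1cccs1)Nc1ccc(Br)cc1`, has not yet been measured. It differs from compound 2 by bromo in place of ethyl on an aromatic carbon. Among the measured compounds shown here, no step between measured compounds that differ in one place is available here, so the size of this change cannot be read from measured pairs. Given that compound 2 gives only a limit of > 100000 nM, the change is expected to produce no step beyond the usual scatter, and the expected step is a step that the limit leaves unreadable from compound 2 to compound 4. Compound 4 is estimated at 150000 nM, with a range from 40000 nM to 600000 nM, and is expected most probably to be reported again only as a limit in this assay.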

Compound 4, concentration for 50% growth inhibition: 4700 nM
Beside the measured number, compound 4's estimate is 32-fold (1.50 log units) above it; the whole stated range lies above it.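

In this assay compound 4 gives 4700 nM, the first measured number among the compounds shown, so the shared core can inhibit the growth of these cells within the range the assay can read. The earlier compounds shown here could not show this, and the new result also shows that the group on this aromatic carbon, para to a large group, can decide whether a number is obtained at all: bromo in place of ethyl gives an at least 21-fold lower number from compound 2 to compound 4 (1.32 log units; beyond the scatter). Compound 2 gives > 100000 nM, a limit of the assay and not a number, so the step marks only the smallest size the change can have: the limit of > 100000 nM in this assay, at which 3 of the 4 values shown sit.

The compounds shown leave open whether the gain belongs to bromo itself or would also appear with chloro, methoxy or an amine at this position, or simply with a hydrogen in place of ethyl. They also leave open whether bromo at another carbon of the same ring would give a measured number, and whether the step would hold in other cell lines.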